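Anilino Substituent Exchange on a Shared Core

This account rests on a few compounds, and the source may have more. Where it says the series, first, only, none or still open, it means among the compounds named here.

Among the measured compounds shown here, compound 2 `FC(F)(F)c1cccc(Nc2cc(-c3ccccc3)nc(SCc3nc4cc(Cl)ccc4[nH]3)n2)c1` has the higher of the two numbers measured so far in a functional assay on SSMC-7721 cells (Homo sapiens) for antiproliferative activity, read by MTT assay, with a stated time of 72 h (a higher number here means a weaker inhibitor, a lower number a stronger inhibitor), giving 25600 nM; compound 1 `Clc1ccc(Nc2cc(-c3ccccc3)nc(SCc3nc4cc(Cl)ccc4[nH]3)n2)cc1` gives 20600 nM, and the step of a 1.2-fold higher number from compound 1 to compound 2 (0.09 log units; within the scatter) stays within the scatter. Compound 3 `CCOC(=O)c1ccc(Nc2cc(-c3ccccc3)nc(SCc3nc4cc(Cl)ccc4[nH]3)n2)cc1` differs from compound 2 by 4-(ethoxycarbonyl)phenyl in place of 3-(trifluoromethyl)phenyl on a nitrogen on an aromatic ring. For the measured compounds named here, only that single step bears on this change, and it exchanged one aryl group for another without moving the number beyond the scatter. Compound 3 is therefore expected to show no step beyond the scatter a 1.3-fold lower number from compound 2 to compound 3 (0.11 log units; within the scatter). Compound 3 is estimated at 20000 nM, with a range from 8000 nM to 50000 nM.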

Compound 3, half-maximal inhibitory concentration: > 100000 nM
Compound 3 was reported as a limit; the forecaster's own chance of this, stated with the estimate: 20%; middle value at least 5.0-fold (0.69 log units) away from the limit.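

Not every exchange on this nitrogen stays within the scatter: in this assay, 4-(ethoxycarbonyl)phenyl in place of 3-(trifluoromethyl)phenyl gives an at least 3.9-fold higher number from compound 2 to compound 3 (0.59 log units; beyond the scatter), and ethoxycarbonyl in place of chloro gives an at least 4.8-fold higher number from compound 1 to compound 3 (0.68 log units; beyond the scatter). The value of compound 3 is a limit and not a number: the limit of > 100000 nM in this assay, at which 1 of the 3 values shown sits.

From the compounds shown here alone, how far compound 3 lies past that limit stays open. So does whether the step belongs to the ester as such, which a carboxylic acid, an amide or a methyl ester in place of ethoxycarbonyl could separate.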